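The compounds below may be only part of what the source reports. "The series", "measured", "known", "first", "only" and "open" are said of these compounds alone.

Measured so far in a functional assay on MCF7 cells (Homo sapiens) for cytotoxicity, read by MTT assay, with a stated time of 24 h; a lower number here means a stronger inhibitor, a higher number a weaker inhibitor:
Compound 1, `COc1ccc(N(CC(=O)NCCC[Te]c2ccccc2)C(=O)CNC(=O)OC(C)(C)C)cc1`, gives 5000 nM.
Compound 2, `COc1ccc(N(CC(=O)NCCC[Se]c2ccccc2)C(=O)CNC(=O)OC(C)(C)C)cc1`, gives only >= 100000 nM, which is a limit of the assay and not a number.

Compound 2 therefore stands at the bottom of what this assay resolves: its result is the limit of >= 100000 nM in this assay, at which 1 of the 2 values shown sits, and no figure for it exists. Among the compounds with values here, the one measured step, an at least 20-fold higher number from compound 1 to compound 2 (1.30 log units; beyond the scatter), concerns the exchange of tellurium for selenium on the chain and says nothing about the carbonyl side of the core.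

Compound 3, `COc1ccc(N(CC(=O)NCCC[Se]c2ccccc2)C(=O)C#Cc2ccccc2)cc1`, is the next compound. Its change from compound 2 is 2-phenylethynyl in place of ((tert-butoxycarbonyl)amino)methyl on a carbonyl carbon. Within the data shown here, no measured step bears on this change, and because compound 2 sits at the limit of >= 100000 nM in this assay, at which 1 of the 2 values shown sits, there is not even a starting number from which a step could be counted. Among the measured compounds shown here, what is expected for compound 3 in this assay rests on no measured precedent, so the estimate is wide; the expected step is an at least 2.5-fold lower number from compound 2 to compound 3 (0.39 log units; beyond the scatter). Compound 3 is expected to give about 40000 nM, estimated between 8000 nM and 200000 nM, with a real chance that the assay again reports only a limit.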

Compound 3, half-maximal inhibitory concentration: >= 100000 nM
Compound 3: a limit, no number; the forecaster's own chance of this, stated with the estimate: 45%; at least 2.5-fold (0.39 log units) between middle value and limit.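

Compound 2 and compound 3 both end at a limit of the assay and not at a number in this assay, so no step can be read between them, because the two limits coincide: the limit of >= 100000 nM in this assay, at which 2 of the 3 values shown sit.

The compounds shown leave open whether 2-phenylethynyl and ((tert-butoxycarbonyl)amino)methyl on a carbonyl carbon differ at all in this read-out.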